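Compound 3 to compound 4: trifluoromethyl in place of bromo

The source may report more compounds than this note shows. Statements on the series, on what has been measured and on what is new or still open speak of the compounds shown alone.

Of the compounds shown here, three sharing one core have been read in a functional assay on U-251 cells (Homo sapiens) for antiproliferative activity, read by MTT assay, with a stated time of 24 h; on this read-out higher numbers stand for weaker inhibition and lower numbers for stronger inhibition. For the measured compounds named here, compound 1 `COc1cc(OC)c(-c2coc3cc(OCc4ccc([N+](=O)[O-])cc4)ccc3c2=O)cc1OC` gives 9400 nM, the only actual number in the set. Compound 2 `COc1cc(OC)c(-c2coc3cc(OCc4ccccc4C(F)(F)F)ccc3c2=O)cc1OC` is reported only as a limit of the assay, > 10000 nM. Going by these compounds, compound 3 `COc1cc(OC)c(-c2coc3cc(OCc4cccc(Br)c4)ccc3c2=O)cc1OC` is likewise reported only as a limit, > 10000 nM, so its true position is unknown.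

Compound 4 `COc1cc(OC)c(-c2coc3cc(OCc4cccc(C(F)(F)F)c4)ccc3c2=O)cc1OC` carries one change: trifluoromethyl in place of bromo on an aromatic carbon. The trifluoromethyl sits on an aromatic carbon, meta to a large group.

The nearest measured steps are an at least 1.0-fold higher number from compound 1 to compound 3 (0.02 log units; that floor lies within the scatter) and an at least 1.0-fold higher number from compound 1 to compound 2 (0.02 log units; that floor lies within the scatter). Both are floors only, and neither shows a change beyond the scatter. Between the two limited compounds stands a step that the two limits leave unreadable from compound 2 to compound 3. None of these steps points to a gain, so no step beyond the scatter is expected in this assay, and another limit reading is likely.

The expected change is a step that the limit leaves unreadable from compound 3 to compound 4. For compound 4 the estimate is 12000 nM, with an expected range of 6000 nM to 25000 nM.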

Compound 4, half-maximal inhibitory concentration: > 10000 nM
Compound 4 ended at the assay's limit; the forecaster's own chance of this, stated with the estimate: 75%; the middle value does not contradict the limit.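

Read in this assay, compound 4 gives only a limit, > 10000 nM. The steps among compound 2, compound 3 and compound 4 cannot be read because all three sit at the same limit: the limit of > 10000 nM in this assay, at which 3 of the 4 values shown sit. For the compounds shown here, the only readable step is a floor, an at least 1.0-fold higher number from compound 1 to compound 4 (0.02 log units; that floor lies within the scatter), so the 3-(trifluoromethyl)phenyl group joins the 3-bromophenyl and 2-(trifluoromethyl)phenyl groups in showing no gain over the 4-nitrophenyl group, and the earlier limit at this position is not confined to bromo.

Going by these compounds, the size of any gap between bromo and trifluoromethyl on this aromatic carbon remains open, with no number on either side. Also open, on these data alone, is whether an amine or a carboxylic acid at the same place would bring a value inside the range of this assay.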